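The source may hold more compounds than are shown below. What is called first, only, known or untested is meant among the compounds shown, and "the series" means these compounds.

Measured so far in a functional assay for activation of Alpha-1A adrenergic receptor (Homo sapiens), read by calcium flux; on this read-out lower numbers stand for an effect already at smaller amounts and higher numbers for an effect only at larger amounts of compound:
Compound 1 `c1ccc(-c2ccncc2)c(OCC2=NCCN2)c1` gives < 100000 nM, which is a limit of the assay and not a number.
Compound 2 `Cc1ccoc1-c1ccccc1OCC1=NCCN1` gives 3.16 nM.

Compound 2 therefore stands as the only plain number shown; the other value is a limit. Among the compounds with values here, the single measured step that the limit leaves unreadable from compound 1 to compound 2 is not readable in size. Compound 3 `Cn1nccc1-c1ccccc1OCC1=NCCN1` carries the change (1-methyl-1H-pyrazol-5-yl in place of 3-methylfuran-2-yl on an aromatic carbon). Within the data shown here, no measured step reads on this swap of one five-membered ring for another, so the expectation rests on compound 2 alone. A step of a 3.8-fold higher number from compound 2 to compound 3 (0.58 log units; beyond the scatter) toward larger amounts is expected. Compound 3 is estimated at 12 nM, within 2 nM to 80 nM.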

Compound 3, half-maximal effective concentration: 39.8 nM
The estimate for compound 3 lay 3.3-fold (0.52 log units) below the measured number; measured number inside the range.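

In this assay, this position on an aromatic carbon, ortho to a group of 7 heavy atoms, turns out to distinguish between two five-membered aromatic rings: the change shows a 13-fold higher number from compound 2 to compound 3 (1.10 log units; beyond the scatter). Both groups count 6 heavy atoms, so the size of the step goes with the change of ring and not with its heavy-atom count. Steps from compound 1 cannot be read, because its value is a limit of the assay: the limit of < 100000 nM in this assay, at which 1 of the 3 values shown sits.

The compounds shown leave open how a 3-methylthiophen-2-yl group or a plain phenyl ring would read here. They also cannot separate the effect of the ring atoms from that of where the methyl group sits.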